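A fluoro in place of hydrogen on compound 2

A few compounds are considered here, and "the series" means these few. Any claim that something is new, unique, unknown or untested is made for them only; others in the source may bear on it.

In a physicochemical assay for solubility (on this read-out lower numbers stand for lower solubility and higher numbers for higher solubility), compound 1 (`COc1ccc(-n2cnc3cnc(-c4ccc(F)cc4C)cc32)cc1OC`) reads > 200000 nM, which is a limit of the assay and not a number. For the measured compounds named here, compound 2 (`COc1ccc(-n2cnc3cnc(-c4ccc(F)cc4C)cc32)cc1`) gives 117000 nM, the only true number available so far. Compound 3 (`COc1ccc(-n2cnc3cnc(-c4ccc(F)cc4C)cc32)cc1F`) differs from it by one change: fluoro in place of hydrogen on an aromatic carbon. This places fluoro in place of hydrogen on an aromatic carbon, ortho to a methoxy group. Going by the values given here, only one measured step bears on this, an at least 1.7-fold lower number from compound 1 to compound 2 (0.23 log units; that floor lies within the scatter), which likewise exchanges a group on an aromatic carbon. Its floor lies within the scatter, so it offers no firm size and no clear direction for the new change. No step beyond the scatter is therefore expected in this assay. The expected step is a 1.2-fold lower number from compound 2 to compound 3 (0.07 log units; within the scatter). Compound 3 is estimated at 100000 nM, with an expected range from 45000 nM to 200000 nM.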

Compound 3, solubility: 49000 nM
Beside the measured number, compound 3's estimate is 2.0-fold (0.31 log units) above it; low and high end bracket the measured number.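

In this assay, the position ortho to a methoxy group proves sensitive to what it carries: hydrogen to fluoro gives a 2.4-fold lower number from compound 2 to compound 3 (0.38 log units; beyond the scatter), whereas the earlier exchange at this position gave only an at least 1.7-fold lower number from compound 1 to compound 2 (0.23 log units; that floor lies within the scatter). Fluoro in place of methoxy at the same position gives an at least 4.0-fold lower number from compound 1 to compound 3 (0.61 log units; beyond the scatter), so compound 3, with fluoro, has the lowest number of the three, with both of its steps beyond the scatter. That second step is a floor and not a size, since compound 1 reads as a limit: the limit of > 200000 nM in this assay, at which 1 of the 3 values shown sits.

As far as these compounds go, whether other groups at this position, such as an amine, a carboxylic acid or a longer chain, would also lower the number remains open. So does the true size of the step from methoxy to fluoro.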